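Swapping Configuration at One Saturated Ring Carbon

This account rests on a few compounds, and the source may have more. Where it says the series, first, only, none or still open, it means among the compounds named here.

Three compounds share one core and differ in the group on an aromatic nitrogen. Compound 1 `Cc1cc2ncccc2cc1Nc1ncc2c(n1)n(C1CCN(C)CC1)c(=O)n2C` carries a 1-methylpiperidin-4-yl group; in a physicochemical assay for lipophilicity, read by HPLC, using the shake flask method, measured as octanol-water partition, at pH 7.4 (on this read-out lower numbers stand for lower lipophilicity and higher numbers for higher lipophilicity), compound 1 gives 1.8. Compound 2 `Cc1cc2ncccc2cc1Nc1ncc2c(n1)n(C1CCNCC1)c(=O)n2C` has hydrogen in place of methyl on the amine nitrogen of that ring, and compound 2 gives 0.5, a change of a number 1.30 log units lower from compound 1 to compound 2 (beyond the scatter). Compound 3 `Cc1cc2ncccc2cc1Nc1ncc2c(n1)n([C@@H]1CCN(C)C1)c(=O)n2C` carries a 1-methylpyrrolidin-3-yl group instead, and compound 3 gives 1.2; the step is a number 0.60 log units lower from compound 1 to compound 3 (beyond the scatter), and from the unmethylated ring it is a number 0.70 log units higher from compound 2 to compound 3 (beyond the scatter). Compound 3 thus stands second highest of the three, with compound 1 above it and compound 2 below it, each beyond the scatter.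

Compound 4 `Cc1cc2ncccc2cc1Nc1ncc2c(n1)n([C@H]1CCN(C)C1)c(=O)n2C` differs from compound 3 only in configuration: the two compounds have the same atoms and bonds and differ only in configuration as drawn: 1 of 1 stereo elements differ; a stereocentre at a saturated ring carbon is drawn R in compound 3 and S in compound 4. Among the compounds with values here, none of the measured steps changes configuration alone; each alters atoms or groups, so none bears directly on this step. With identical atoms and bonds, no shift beyond the scatter is expected, and the step from compound 3 to compound 4 is estimated as no change at the digits printed from compound 3 to compound 4 (within the scatter). Compound 4 is therefore expected to give 1.2, within 0.9 to 1.5.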

Compound 4, distribution coefficient: 1.1
Compound 4: the middle estimate sits 0.10 log units above what was measured; low and high end bracket the measured number.
By their numbers in this assay, from the lowest: compound 2; then compounds 4 and 3 (each within the scatter of the next); then compound 1.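

In this assay, within the data shown here, the configuration at this saturated ring carbon is the first thing tested on its own, and the step is a number 0.10 log units lower from compound 3 to compound 4 (within the scatter). That step can be read as the effect of this stereocentre alone because nothing else separates the pair: the fact that compounds 3 and 4 differ only in the configuration as drawn. The ring comparisons made with compound 3 also hold for the other configuration, with a number 0.60 log units higher from compound 2 to compound 4 (beyond the scatter) and a number 0.70 log units lower from compound 1 to compound 4 (beyond the scatter), so at this position the choice of ring and its substituent separates these compounds, while the drawn configuration does not.

The compounds shown leave open how a larger group on the ring nitrogen, such as ethyl or acetyl, would fare in either configuration. They also leave open whether a stereocentre on a different ring, such as a 1-methylpiperidin-3-yl group, would behave in the same way.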